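The source may report more compounds than this note shows. Statements on the series, on what has been measured and on what is new or still open speak of the compounds shown alone.

Compound 1: `CCCCC[Se]c1nc(NCc2ccccc2)c2ccccc2n1` — > 100000 nM
Compound 2: `C[Se]c1nc(NCc2ccccc2)c2ccccc2n1` — 12400 nM

Compound 1, `CCCCC[Se]c1nc(NCc2ccccc2)c2ccccc2n1`, reaches only a limit in an ADME assay on 184B5 cells (Homo sapiens) for cytotoxicity, read by MTT assay, with a stated time of 72 h (on this read-out higher numbers stand for weaker inhibition of growth and lower numbers for stronger inhibition of growth), giving > 100000 nM, which is a limit of the assay and not a number. Compound 2, `C[Se]c1nc(NCc2ccccc2)c2ccccc2n1`, gives 12400 nM in this assay. Between them there is one measured step, an at least 8.0-fold lower number from compound 1 to compound 2 (0.90 log units; beyond the scatter); this rests on the limit (the limit of > 100000 nM in this assay, at which 1 of the 2 values shown sits) and so its full size is not known. Going by the values given here, compound 2 therefore stands as the only compound with an actual number; the other value shown is a limit.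

Compound 3, `CSc1nc(NCc2ccccc2)c2ccccc2n1`, differs from compound 2 in one place: a group of 2 heavy atoms (1 carbon, 1 sulfur; no ring) in place of a group of 2 heavy atoms (1 carbon, 1 selenium; no ring), on an aromatic carbon. Among the compounds with values here, no measured step bears on this exchange; the one step known concerns the chain on the selenium atom, not the selenium itself. With nothing to point the other way, compound 3 is expected to stay within the scatter of compound 2, a step of a 1.2-fold higher number from compound 2 to compound 3 (0.08 log units; within the scatter) in this assay. Compound 3 is thus estimated at 15000 nM in this assay, within a range of 5000 nM to 45000 nM.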

Compound 3, concentration for total growth inhibition: > 100000 nM
Compound 3: only a limit was reported (the forecaster's own chance of this, stated with the estimate: 10%); middle value at least 6.6-fold (0.82 log units) away from the limit.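

In this assay, the atom that links the methyl group to the aromatic carbon between two ring nitrogen atoms proves to matter: methylsulfanyl in place of the selenium group gives an at least 8.0-fold higher number from compound 2 to compound 3 (0.90 log units; beyond the scatter), and the full size of this step is not known. Going by these compounds alone, the short chain on selenium is therefore not enough alone, as the same methyl group on sulfur does not retain the stronger inhibition of growth seen with compound 2, which remains the only compound with an actual number. The step from compound 1 to compound 3 cannot be read because both values are limits: the limit of > 100000 nM in this assay, at which 2 of the 3 values shown sit.

The compounds shown leave open how an ethyl chain on selenium would compare with the methyl group of compound 2. They also leave open whether an amine or a methoxy group at this position would give a measurable number.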